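A few compounds are considered here, and "the series" means these few. Any claim that something is new, unique, unknown or untested is made for them only; others in the source may bear on it.

Working notes on the series. Three analogues of one core have so far been run in a functional assay on the whole organism (strain albino) for inhibition, with Rattus norvegicus as the target, read by paw edema, with stated times of 1 h and 2 h, at a dose of 20 mmol/kg by the intraperitoneal route; on this read-out lower numbers stand for less inhibition and higher numbers for more inhibition at the one dose given (going by the name of the read-out). Compound 1 `N#CC1=C(NCC(=O)N2CCCC2)N(c2ccccc2)C(=O)N2CCCCC(N3CCCC3)C12` gives 49.8%, compound 2 `N#CC1=C(/N=C/c2ccccc2)N(c2ccccc2)C(=O)N2CCCCC(N3CCCC3)C12` gives 75.9%, and compound 3 `CCOC(=O)C(=O)NC1=C(C#N)C2C(N3CCCC3)CCCCN2C(=O)N1c1ccccc1` gives 83.6%, the highest of the three numbers, though its gap to compound 2 is within the scatter. Compound 4 `N#CC1=C(/N=C/Nc2ccccc2)N(c2ccccc2)C(=O)N2CCCCC(N3CCCC3)C12` is not yet measured; relative to compound 3 the change is a group of 9 heavy atoms (7 carbon, 2 nitrogen; one six-membered aromatic ring of carbon only) in place of a group of 8 heavy atoms (4 carbon, 1 nitrogen, 3 oxygen; no ring), on a double-bonded ring carbon. Going by the values given here, the steps that bear on this are a number 26.1 percentage points higher from compound 1 to compound 2 (beyond the scatter), a number 33.8 percentage points higher from compound 1 to compound 3 (beyond the scatter) and, most directly, a number 7.7 percentage points higher from compound 2 to compound 3 (within the scatter). The group entering compound 4 carries an aromatic ring and a double bond outside it, as the group that left in that last step did. The step of a number 7.6 percentage points lower from compound 3 to compound 4 (within the scatter) is therefore expected to stay within the scatter. Compound 4 is expected to give 76%, with a range from 60% to 90%.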

Compound 4, a percentage reported as inhibition, in the whole organism at one dose (the size of the read-out at that dose, not a potency): 47.5%
Beside the measured number, compound 4's estimate is 28.5 percentage points above it, and the stated range ends above it.
By their numbers in this assay, from the lowest: compounds 4 and 1 (each within the scatter of the next); then compounds 2 and 3 (each within the scatter of the next).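

In this assay, an aromatic ring and a double bond outside it in the entering group do not by themselves hold the number at this double-bonded ring carbon: anilino in place of phenyl on the carbon with a double bond to nitrogen gives a number 28.4 percentage points lower from compound 2 to compound 4 (beyond the scatter), so the single added nitrogen separates two otherwise matching groups. Replacing ((ethoxycarbonyl)carbonyl)amino gives a number 36.1 percentage points lower from compound 3 to compound 4 (beyond the scatter), while a number 2.3 percentage points lower from compound 1 to compound 4 (within the scatter) shows no separation from the ring-bearing amide group. Nothing measured here explains these differences.

Still open, as far as these compounds go, is whether a carboxylic acid in place of the ethoxycarbonyl end would keep the number. A methyl group in place of the phenyl on the carbon with a double bond to nitrogen is equally untested among these compounds.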